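From 3,4-difluorophenyl to 2,3-dimethylphenyl on the sulfonamide

The compounds below may be only part of what the source reports. "The series", "measured", "known", "first", "only" and "open" are said of these compounds alone.

Of the compounds shown here, three that share one core have been measured in a functional assay on HT-29 cells (Homo sapiens) for antiproliferative activity, read by sulforhodamine B assay, with a stated time of 48 h; on this read-out higher numbers stand for weaker inhibition and lower numbers for stronger inhibition. Compound 1 `O=C1NCCN1c1ccc(S(=O)(=O)Nc2ccc(F)cc2)cc1` gives 370 nM, compound 2 `O=C1NCCN1c1ccc(S(=O)(=O)Nc2ccccc2)cc1` gives 280 nM, and compound 3 `O=C1NCCN1c1ccc(S(=O)(=O)Nc2ccc(F)c(F)c2)cc1` gives 350 nM. These three numbers cannot be told apart, so compound 3 stands level with the other two. Its nearest neighbour is compound 1, with a 1.1-fold lower number from compound 1 to compound 3 (0.02 log units; within the scatter). Taking away the fluoro of compound 1 makes just as little difference, with a 1.3-fold lower number from compound 1 to compound 2 (0.12 log units; within the scatter).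

Compound 4 `Cc1cccc(NS(=O)(=O)c2ccc(N3CCNC3=O)cc2)c1C` has not yet been measured. Its change from compound 3 is larger in kind: 2,3-dimethylphenyl in place of 3,4-difluorophenyl on a sulfonamide nitrogen, which puts 2,3-dimethylphenyl in place of 3,4-difluorophenyl on a sulfonamide nitrogen. Going by the values given here, the closest guide is a 1.3-fold higher number from compound 2 to compound 3 (0.10 log units; within the scatter), the one measured step that replaces the whole group at that place. Among the compounds with values here, all the measured steps only exchange hydrogen and fluoro, and no measured compound carries a methyl, so the guidance is limited and the range has to stay wide. The expected step in this assay is a 1.1-fold higher number from compound 3 to compound 4 (0.06 log units; within the scatter), which means no change beyond the scatter is expected. For compound 4 the estimated value is 400 nM, with an expected range from 130 nM to 1300 nM.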

Compound 4, half-maximal inhibitory concentration: 190 nM
For compound 4 the middle estimate is 2.1-fold (0.32 log units) above the measured one, within the range that was stated.
By their numbers in this assay, from the lowest: compounds 4, 2, 3 and 1 (each within the scatter of the next).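

In this assay, the sulfonamide nitrogen accepts the 2,3-dimethylphenyl group without a change that can be told apart from the scatter: the steps are a 1.8-fold lower number from compound 3 to compound 4 (0.27 log units; within the scatter), a 1.5-fold lower number from compound 2 to compound 4 (0.17 log units; within the scatter) and a 1.9-fold lower number from compound 1 to compound 4 (0.29 log units; within the scatter), and all three are within it. Going by these compounds alone, the earlier steps only exchanged hydrogen and fluoro on this ring, so compound 4 is the first sign that methyl groups can stand on it and that the whole set of four compounds still sits level, with the phenyl of compound 2, the 4-fluorophenyl of compound 1 and the 3,4-difluorophenyl of compound 3 all in the same band. Nothing is available that would explain this flat picture at the position.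

From the compounds shown here alone, it remains open how far this tolerance goes, for instance whether a phenyl carrying an amine or a carboxylic acid, or a longer alkyl chain in place of the ring, would keep the number in the same band. Going by these compounds, whether a phenyl with a single methyl would read the same as compound 4 also remains open.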